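A few compounds are considered here, and "the series" means these few. Any claim that something is new, unique, unknown or untested is made for them only; others in the source may bear on it.

Measured so far:
- compound 1 `Cc1cn(/C=C/C=O)c(=O)[nH]c1=O`: 25000 nM
- compound 2 `O=C/C=C/n1ccc(=O)[nH]c1=O`: 30000 nM

In a functional assay on HeLa cells (Homo sapiens) for inhibition (on this read-out lower numbers stand for stronger inhibition and higher numbers for weaker inhibition), compound 2 gives 30000 nM, within the scatter of compound 1 at 25000 nM, so neither compound stands apart from the other.

Compound 3 `O=C/C=C/n1cc(F)c(=O)[nH]c1=O` differs from compound 2 by fluoro in place of hydrogen on an aromatic carbon.

Going by the values given here, the only measured step, a 1.2-fold higher number from compound 1 to compound 2 (0.08 log units; within the scatter), is hydrogen in place of methyl on an aromatic carbon. Among the compounds with values here, it bears on this change only indirectly, since no measured compound carries fluoro. With this single small step as the guide, no shift beyond the scatter is expected in this assay, although the support is thin and the range is kept wide.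

The expected size of the change is a 1.5-fold lower number from compound 2 to compound 3 (0.18 log units; within the scatter). For compound 3 the estimated value is 20000 nM, with an expected range of 5000 nM to 40000 nM.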

Compound 3, half-maximal inhibitory concentration: 40000 nM
Compound 3: the middle estimate sits 2.0-fold (0.30 log units) below what was measured; the range from low to high includes it.
By their numbers in this assay, from the lowest: compounds 1, 2 and 3 (each within the scatter of the next).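

In this assay, fluoro in place of hydrogen on the aromatic carbon gives a 1.3-fold higher number from compound 2 to compound 3 (0.12 log units; within the scatter), and fluoro in place of methyl at the same carbon gives a 1.6-fold higher number from compound 1 to compound 3 (0.20 log units; within the scatter). Going by these compounds alone, this position has now carried hydrogen, methyl and fluoro, and no pair among compounds 1, 2 and 3 separates beyond the scatter, so fluoro does not stand apart from the other two substituents in this read-out. No supporting data are available to explain this result.

From the compounds shown here alone, it remains open whether an amine, a carboxylic acid or a longer chain at this aromatic carbon would move the number beyond the scatter. Going by these compounds, the contribution of the 2-formylethenyl group also remains open, as compounds 1, 2 and 3 all carry it unchanged.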